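From furan-3-yl to ethynyl: an expected gain in potency

The compounds below may be only part of what the source reports. "The series", "measured", "known", "first", "only" and "open" are said of these compounds alone.

In a functional assay on HCT-116 cells (Homo sapiens), read by MTT assay, with a stated time of 72 h (on this read-out lower numbers stand for stronger inhibition and higher numbers for weaker inhibition), compound 2 (`Cc1ncnc2c1c(-c1ccoc1)cn2[C@@H]1O[C@H](CO)[C@@H](O)[C@H]1O`) gives > 20000 nM. This value is a limit of the assay and not a number. Compound 2 therefore stands at the limit of > 20000 nM in this assay, at which 1 of the 2 values shown sits. Going by the values given here, the only other measured compound is compound 1 (`C#Cc1cn([C@@H]2O[C@H](CO)[C@@H](O)[C@H]2O)c2ncnc(SC)c12`), which carries an ethynyl group and gives 30 nM in this assay.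

The next compound, compound 3 (`C#Cc1cn([C@@H]2O[C@H](CO)[C@@H](O)[C@H]2O)c2ncnc(C)c12`), keeps the rest of compound 2 and changes one group: ethynyl in place of furan-3-yl on an aromatic carbon. Among the compounds with values here, no two measured compounds differ in only one place, so no measured step guides this change directly, and compound 1 is only a loose guide. Even so, a large move toward stronger inhibition is expected in this assay, since compound 1 gives 30 nM with ethynyl in that place. The estimated change is an at least 200-fold lower number from compound 2 to compound 3 (2.30 log units; beyond the scatter). For compound 3 the expected value is 100 nM, with an estimated range from 15 nM to 1500 nM.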

Compound 3, half-maximal inhibitory concentration: > 20000 nM
Compound 3: only a limit was reported (the forecaster's own chance of this, stated with the estimate: 8%); at least 200-fold (2.30 log units) between middle value and limit.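

Compound 3 shows that ethynyl at this place does not by itself give strong inhibition. With ethynyl kept, methyl in place of methylsulfanyl on an aromatic carbon gives an at least 660-fold higher number from compound 1 to compound 3 (2.82 log units; beyond the scatter), so in this assay the strong inhibition of compound 1 depends on the methylsulfanyl group as well as on ethynyl. Going by these compounds alone, the earlier compounds could not show this, as compound 1 and compound 2 differ in more than one place, and this is the first step that isolates a single change. The reading for compound 3 is a limit of the assay and not a number, as is the reading for compound 2, so the step between them cannot be read, and neither ethynyl nor furan-3-yl can be ranked on the methyl-bearing core: the limit of > 20000 nM in this assay, at which 2 of the 3 values shown sit.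

From the compounds shown here alone, it remains open how furan-3-yl would behave with methylsulfanyl in the other place, on the core of compound 1. Going by these compounds, it is also open whether an amine or a longer sulfur-linked chain, such as ethylsulfanyl, in place of methylsulfanyl would keep the inhibition seen with compound 1.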